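Methoxy in place of methyl on the core of compound 2

The source may report more compounds than this note shows. Statements on the series, on what has been measured and on what is new or still open speak of the compounds shown alone.

Measured so far:
- compound 1 `CC(C)c1ccccc1-c1nccc(NCc2ccc(-c3cccnc3)cc2)n1` gives 150 nM
- compound 2 `Cc1cnc(-c2ccccc2C(C)C)nc1NCc1ccc(-c2cccnc2)cc1` gives 70 nM
- compound 3 `Cc1nc(-c2ccccc2C(C)C)nc(NCc2ccc(-c3cccnc3)cc2)c1C` gives 120 nM

In an assay on a protein complex for inhibition of ubiquitin carboxyl-terminal hydrolase 1/WD repeat-containing protein 48 (Homo sapiens), read by fluorescence (a higher number here means a weaker inhibitor, a lower number a stronger inhibitor), compound 2 has the lowest number of the three. The step of a 2.1-fold lower number from compound 1 to compound 2 (0.33 log units; beyond the scatter) lies beyond the scatter, while the step of a 1.7-fold higher number from compound 2 to compound 3 (0.23 log units; within the scatter) lies within it, so compound 2 and compound 3 cannot be told apart.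

Compound 4 `COc1cnc(-c2ccccc2C(C)C)nc1NCc1ccc(-c2cccnc2)cc1` differs from compound 2 by methoxy in place of methyl on an aromatic carbon. Both measured steps at this position add a methyl; none swaps a methyl for a methoxy, so they bear only loosely on this change. A step of no more than the usual scatter is therefore expected, with the number for compound 4 estimated at 90 nM (range 40 nM to 250 nM), meaning an expected step of a 1.3-fold higher number from compound 2 to compound 4 (0.11 log units; within the scatter).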

Compound 4, half-maximal inhibitory concentration: 70 nM
Compound 4: the middle estimate sits 1.3-fold (0.11 log units) above what was measured, within the range that was stated.
By their numbers in this assay, from the lowest: compounds 2, 4, 3 and 1 (each within the scatter of the next, the first and the last beyond it).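

Methoxy can replace methyl on this aromatic carbon with no change at the digits printed from compound 2 to compound 4 (within the scatter) as the step, so this position accepts a second heavy atom, an oxygen counted as a hydrogen-bond acceptor, with no loss. Methoxy in place of hydrogen gives a 2.1-fold lower number from compound 1 to compound 4 (0.33 log units; beyond the scatter) as its step, the same size as the step seen with methyl. No measured evidence accounts for this match. The compounds shown leave open how an ethyl group, a chlorine atom or an amine at this carbon would compare.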